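This account rests on a few compounds, and the source may have more. Where it says the series, first, only, none or still open, it means among the compounds named here.

Three compounds sharing one core have been run in a functional assay on MGC-803 cells (Homo sapiens) for antiproliferative activity, read by MTT assay, with a stated time of 72 h; on this read-out lower numbers stand for stronger inhibition and higher numbers for weaker inhibition. Compound 1 `CCCSc1nc(N/N=C/c2cc(OC)c(OC)c(OC)c2)c2nnn(Cc3ccccc3)c2n1` gives 9410 nM in this assay. Compound 3 `C#CCSc1nc(N/N=C/c2ccc(N(C)C)cc2)c2nnn(Cc3ccccc3)c2n1` gives 7620 nM, a number that lies within the usual scatter of the value for compound 1, so the two cannot be ranked against each other. Compound 2 `CCCSc1nc(N/N=C/c2cccnc2)c2nnn(Cc3ccccc3)c2n1` gives 38100 nM, which sits beyond the scatter on the weaker side of compound 1. Of the three numbers, that of compound 1 is the second highest, with compound 3 nearest and compound 2 furthest.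

Compound 4 `COc1cc(/C=N/Nc2nc(SCc3ccccc3)nc3c2nnn3Cc2ccccc2)cc(OC)c1OC` has not yet been measured. It differs from compound 1 in one place: phenyl in place of ethyl on a saturated chain carbon bound to a sulfur. Put another way, the propylsulfanyl of compound 1 becomes benzylsulfanyl in compound 4, while the rest of the structure is kept. Within the data shown here, no pair of measured compounds shows this change, so there is no directly comparable step to lean on. For compound 4 the step of a 1.3-fold lower number from compound 1 to compound 4 (0.13 log units; within the scatter) is expected to be small, most likely within the scatter, with the direction uncertain. Compound 4 is therefore estimated at 7000 nM in this assay, with a range from 2500 nM to 20000 nM.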

Compound 4, half-maximal inhibitory concentration: 1320 nM
Beside the measured number, compound 4's estimate is 5.3-fold (0.72 log units) above it; measured number below the stated range.
By their numbers in this assay, from the lowest: compound 4; then compounds 3 and 1 (each within the scatter of the next); then compound 2.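

In this assay, the group on the sulfur proves to matter: with the rest of the structure kept, phenyl in place of ethyl on the saturated chain carbon bound to a sulfur gives a 7.1-fold lower number from compound 1 to compound 4 (0.85 log units; beyond the scatter). Among these compounds, the earlier compounds offered no pair differing in one place, so this is the first direct reading of this position, and it shows that changing propylsulfanyl to benzylsulfanyl can shift the antiproliferative number beyond the usual scatter. No measurement at hand explains this step.

A single pair cannot show whether the aromatic ring itself is what counts, or whether a longer chain such as hexyl, or a saturated cyclohexyl ring in place of the phenyl, would do the same. It also leaves open how a benzyl group carrying a fluorine or a methoxy group would compare.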